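This account rests on a few compounds, and the source may have more. Where it says the series, first, only, none or still open, it means among the compounds named here.

Compound 2 `O=C(CCc1ccc(-c2ccccc2F)cc1)N1CCCC1` gives the lower of the two numbers measured in an assay on HEK293 cells for inhibition of N-acylethanolamine-hydrolyzing acid amidase (Rattus norvegicus), read by LC-MS, with a stated time of 30 min (on this read-out higher numbers stand for weaker inhibition and lower numbers for stronger inhibition), where compound 2 gives 2800 nM. Going by the values given here, compound 1 `Cc1cccc(-c2ccc(CCC(=O)N3CCCC3)cc2)c1` gives 16500 nM in the same assay, and the step of a 5.9-fold lower number from compound 1 to compound 2 (0.77 log units; beyond the scatter) is the only measured step; it swaps one whole ring for another on the aromatic carbon. Compound 3 `O=C(CCc1ccc(-c2ccc(F)cc2)cc1)N1CCCC1` differs from compound 2 only in where the fluorine sits on the attached ring: 4-fluorophenyl in place of 2-fluorophenyl on an aromatic carbon. Among the compounds with values here, no measured step concerns this kind of shift, and the single known step, which exchanged one ring for a different one, bears on it only loosely. With nothing to suggest a large move, compound 3 is expected to stay close to compound 2. The expected step is a 1.4-fold lower number from compound 2 to compound 3 (0.15 log units; within the scatter), within the scatter. The estimated value for compound 3 in this assay is 2000 nM, within a range from 600 nM to 7000 nM.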

Compound 3, half-maximal inhibitory concentration: 3400 nM
For compound 3 the middle estimate is 1.7-fold (0.23 log units) below the measured one; the range from low to high includes it.
By their numbers in this assay, from the lowest: compounds 2 and 3 (each within the scatter of the next); then compound 1.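

In this assay the place of the fluorine on the attached ring makes no readable difference: the result is a 1.2-fold higher number from compound 2 to compound 3 (0.08 log units; within the scatter) and so 2-fluorophenyl and 4-fluorophenyl cannot be ranked on these numbers. Going by these compounds alone, the earlier compounds could not show this, since their only step exchanged one substituted ring for a differently substituted one. The new comparison with the 3-methylphenyl ring, a 4.9-fold lower number from compound 1 to compound 3 (0.69 log units; beyond the scatter) in the same direction as the step to compound 2, shows that the lower number is not tied to a single fluorine placement.

Still open, going by these compounds, is whether methyl itself or its place on the ring accounts for the higher number of compound 1, and how a ring carrying an amine or a carboxylic acid would behave at this position. Nothing at hand offers an explanation for these results.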